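The source may hold more compounds than are shown below. What is called first, only, known or untested is meant among the compounds shown, and "the series" means these compounds.

Measured so far:
compound 1 `COc1ccc2c(=O)c(/C=C/C(=O)Nc3ccccc3)coc2c1` gives 51000 nM
compound 2 `CCOc1ccc(NC(=O)/C=C/c2coc3cc(OC)ccc3c2=O)cc1` gives > 100000 nM
compound 3 `COc1ccc2c(=O)c(/C=C/C(=O)NCc3ccccc3F)coc2c1` gives > 100000 nM

In a functional assay on A549 cells (Homo sapiens) for inhibition, read by MTT assay, with a stated time of 48 h (a higher number here means a weaker inhibitor, a lower number a stronger inhibitor), compound 1 gives 51000 nM, a genuine number. For compound 2 the assay reports no number but only a limit, > 100000 nM. For compound 3 the same holds: its result, > 100000 nM, is a limit, not a measured concentration. Compound 3 thus stands at the limit of > 100000 nM in this assay, at which 2 of the 3 values shown sit, where its true potency can only be said to lie beyond the range the assay reads.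

Compound 4 `COc1ccc2c(=O)c(/C=C/C(=O)Nc3ccccc3C)coc2c1` is the next member to be tested. Its change from compound 3 is 2-methylphenyl in place of 2-fluorobenzyl on an amide-type nitrogen. The benzyl linker is gone, and a ring carrying a methyl group is attached directly to the amide-type nitrogen, as the plain phenyl is in compound 1.

Going by the values given here, two measured steps bear on this. The step of an at least 1.9-fold higher number from compound 1 to compound 3 (0.29 log units; that floor lies within the scatter) shows that moving from phenyl to 2-fluorobenzyl pushed the value out of the readable range. The step that the two limits leave unreadable from compound 2 to compound 3 gives no usable size. Since compound 4 restores the direct aryl amide seen in compound 1, a return toward that region is expected, that is an at least 1.4-fold lower number from compound 3 to compound 4 (0.15 log units; that floor lies within the scatter) is the expected step. Compound 4 is therefore estimated at 70000 nM, within a range from 30000 nM to 150000 nM.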

Compound 4, half-maximal inhibitory concentration: 23400 nM
For compound 4 the middle estimate is 3.0-fold (0.48 log units) above the measured one; the measured number lies below the stated range.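

In this assay, adding a methyl group to the ring on the amide-type nitrogen gives the first step of readable size in this series, with a 2.2-fold lower number from compound 1 to compound 4 (0.34 log units; beyond the scatter) making compound 4 the strongest of the four compounds shown. The 2-methylphenyl group also compares well with the two other groups on that nitrogen, with an at least 4.2-fold lower number from compound 3 to compound 4 (0.63 log units; beyond the scatter) against 2-fluorobenzyl and an at least 4.2-fold lower number from compound 2 to compound 4 (0.63 log units; beyond the scatter) against 4-ethoxyphenyl, so a substituent on this ring can go with a stronger result, although compound 2 goes against any general rule that added groups help. As far as these compounds go, both of those steps start from a limit rather than a measured number, so they give only a floor and their true sizes stay unknown: the limit of > 100000 nM in this assay, at which 2 of the 4 values shown sit.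

The compounds shown leave open whether the gain is particular to methyl or would also appear with another group at that place, such as an amine, a carboxylic acid or a longer chain like propyl. They also leave open whether adding a second methyl group to the same ring would move the value further in either direction.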